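Benzyl-sulfanyl chalcone-type inhibitors of prostate cancer cell growth

The source may hold more compounds than are shown below. What is called first, only, known or untested is meant among the compounds shown, and "the series" means these compounds.

Measured compounds:
compound 1 `COc1ccccc1/C=C(/SCc1ccc(F)cc1)C(=O)c1ccc(Cl)cc1`: 10000 nM
compound 2 `COc1ccccc1/C=C(/SCc1ccc(C)cc1)C(=O)c1ccc(Cl)cc1`: 10000 nM
compound 3 `CN(C)c1ccc(/C=C(/SCc2ccc(F)cc2)C(=O)c2ccc(Cl)cc2)cc1`: 50000 nM

All three compounds were tested in a functional assay on DU-145 cells (Homo sapiens) for inhibition, read by trypan blue exclusion, with a stated time of 96 h; on this read-out higher numbers stand for weaker inhibition of growth and lower numbers for stronger inhibition of growth. In this assay compound 1 gives 10000 nM and compound 2 gives 10000 nM; the two numbers lie within the scatter of each other, so no change at the digits printed from compound 1 to compound 2 (within the scatter). The structural change between them is methyl in place of fluoro on an aromatic carbon. Compound 3 differs from compound 1 in its core: 4-(dimethylamino)phenyl in place of 2-methoxyphenyl on a double-bonded chain carbon bound to a double-bonded chain carbon. In this assay compound 3 gives 50000 nM, and a 5.0-fold higher number from compound 1 to compound 3 (0.70 log units; beyond the scatter), which leaves compound 3 with the highest number of the three.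

Compound 4 `Cc1ccc(CS/C(=C/c2ccc(N(C)C)cc2)C(=O)c2ccc(Cl)cc2)cc1` has not been measured. It is made from compound 3 by methyl in place of fluoro on an aromatic carbon, which is the same change, at the same place, as that from compound 1 to compound 2. Because that change gave no change at the digits printed from compound 1 to compound 2 (within the scatter), the step from compound 3 to compound 4 is expected to be small as well, no change at the digits printed from compound 3 to compound 4 (within the scatter). For compound 4 in this assay the estimate is therefore 50000 nM, with a likely range from 20000 nM to 120000 nM. This rests on a single measured pair, so the expectation is held loosely.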

Compound 4, concentration for 50% growth inhibition: > 100000 nM
Compound 4 was reported as a limit; the forecaster's own chance of this, stated with the estimate: 25%; middle value at least 2.0-fold (0.30 log units) from the limit.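

In this assay compound 4 gives > 100000 nM, which is a limit of the assay and not a number: the limit of > 100000 nM in this assay, at which 1 of the 4 values shown sits. Methyl in place of fluoro on the benzyl ring therefore reads as an at least 2.0-fold higher number from compound 3 to compound 4 (0.30 log units; that floor lies within the scatter), so this swap may carry over from the core of compound 1 to the core of compound 3 with the same small size, or it may count for more on the second core, and the data cannot decide between the two: the same change on two cores in this assay, no change at the digits printed (within the scatter) from compound 1 to compound 2 and an at least 2.0-fold higher number (0.30 log units; that floor lies within the scatter) from compound 3 to compound 4; the limit leaves it open whether they differ. Seen the other way round, 4-(dimethylamino)phenyl in place of 2-methoxyphenyl reads as an at least 10-fold higher number from compound 2 to compound 4 (1.00 log units; beyond the scatter), which points the same way as the step measured with the fluoro group, though the two steps cannot be shown to match or to differ: the same change on two cores in this assay, a 5.0-fold higher number (0.70 log units; beyond the scatter) from compound 1 to compound 3 and an at least 10-fold higher number (1.00 log units; beyond the scatter) from compound 2 to compound 4; the limit leaves it open whether they differ.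

The compounds shown leave open what number compound 4 would give in a test that reached beyond its limit, and so how large the methyl-for-fluoro step really is on this core. They also leave open how other groups at the same place on the benzyl ring, such as a chlorine atom, a methoxy group or a carboxylic acid, would behave on either core.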